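Chromone dithiocarbamates: removing the methoxy on the piperidine analogue

The source may hold more compounds than are shown below. What is called first, only, known or untested is meant among the compounds shown, and "the series" means these compounds.

Working notes on a small set of chromone dithiocarbamates. Compound 2 `COc1ccc2occ(CSC(=S)N3CCCC3)c(=O)c2c1` and compound 1 `O=c1c(CSC(=S)N2CCCC2)coc2ccccc12` differ only in hydrogen in place of methoxy on an aromatic carbon. Compound 3 `COc1ccc2occ(CSC(=S)N3CCCCC3)c(=O)c2c1` keeps the methoxy of compound 2 and differs from it in piperidin-1-yl in place of pyrrolidin-1-yl on a thiocarbonyl carbon. Compound 4 `O=c1c(CSC(=S)N2CCCCC2)coc2ccccc12` is unmeasured; from compound 3 it differs in hydrogen in place of methoxy on an aromatic carbon, and since the place described is word for word the same as for the pair of compound 2 and compound 1, this is the same change made on the other core.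

In a functional assay on MCF7 cells (Homo sapiens) for antiproliferative activity, read by MTT assay, with a stated time of 72 h (a lower number here means a stronger inhibitor, a higher number a weaker inhibitor), compound 2 gives 34100 nM. Compound 1 gives only a limit here, > 25000 nM, which is the limit of > 25000 nM in this assay, at which 1 of the 3 values shown sits. Compound 3 also gives only a limit, > 40000 nM, that is the limit of > 40000 nM in this assay, at which 1 of the 3 values shown sits. Hence a step that the limit leaves unreadable from compound 2 to compound 1, and an at least 1.1-fold higher number from compound 2 to compound 3 (0.06 log units; that floor lies within the scatter). Within the data shown here, all three measured compounds sit at or beyond the weak end of this assay; no compound can be called stronger or weaker than another.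

For compound 4 the expectation rests on compound 3 giving only a limit, > 40000 nM. It rests too on compound 1 giving only a limit, > 25000 nM. The step from compound 3 to compound 4 is therefore expected to be about a step that the limit leaves unreadable from compound 3 to compound 4, which amounts to no readable change. Compound 4 is estimated at 50000 nM, expected between 25000 nM and 150000 nM, most likely reported as a limit rather than a number.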

Compound 4, half-maximal inhibitory concentration: 1700 nM
Estimate against measurement, compound 4: 29-fold (1.47 log units) above, and the stated range ends above it.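

In this assay, hydrogen in place of methoxy gives an at least 23-fold lower number from compound 3 to compound 4 (1.37 log units; beyond the scatter), and piperidin-1-yl in place of pyrrolidin-1-yl on the core without the methoxy gives an at least 14-fold lower number from compound 1 to compound 4 (1.16 log units; beyond the scatter). The exchange of pyrrolidin-1-yl for piperidin-1-yl therefore does not carry over from one core to the other at the same size: the same change on two cores in this assay, an at least 1.1-fold higher number (0.06 log units; that floor lies within the scatter) from compound 2 to compound 3 and an at least 14-fold lower number (1.16 log units; beyond the scatter) from compound 1 to compound 4, at least 17-fold (1.23 log units) apart, beyond the scatter of two such steps. Compound 1 stands at a limit, > 25000 nM, so the step for hydrogen in place of methoxy on the pyrrolidin-1-yl compounds cannot be read, and whether that change carries from one core to the other is not shown.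

Among these compounds, the only readable gain in this set lies in compound 4, the one compound that combines hydrogen on the aromatic carbon with piperidin-1-yl, so a single compound in a single cell line carries the finding. Still open, from the compounds shown here alone, is whether other amines on the thiocarbonyl carbon, such as morpholine or diethylamine, or other groups in place of methoxy, such as chlorine or ethoxy, would follow compound 4 or stay with the weak compounds.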